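Working notes: isobutoxycarbonyl to butoxycarbonyl on the shared core

The compounds below may be only part of what the source reports. "The series", "measured", "known", "first", "only" and "open" are said of these compounds alone.

- compound 1 `CCCOC(=O)N1CCCc2cc(S(=O)(=O)N3CC(c4ccccc4)NC3=O)ccc21`: > 20000 nM (a limit)
- compound 2 `CC(C)COC(=O)N1CCCc2cc(S(=O)(=O)N3CC(c4ccccc4)NC3=O)ccc21`: 2380 nM

In a functional assay on K562 cells (Homo sapiens) for antiproliferative activity, read by MTT assay (on this read-out higher numbers stand for weaker inhibition and lower numbers for stronger inhibition), compound 1 gives only a limit, > 20000 nM. Among the compounds with values here, compound 2, at 2380 nM, therefore holds the only true number so far.

Compound 3 `CCCCOC(=O)N1CCCc2cc(S(=O)(=O)N3CC(c4ccccc4)NC3=O)ccc21` keeps the shared core and rearranges the chain: propyl in place of isopropyl on a saturated chain carbon bound to an oxygen next to a carbonyl group. This is propyl in place of isopropyl on a saturated chain carbon bound to an oxygen next to a carbonyl group, which also reads as isobutoxycarbonyl to butoxycarbonyl.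

Within the data shown here, one measured step bears on this change: an at least 8.4-fold lower number from compound 1 to compound 2 (0.92 log units; beyond the scatter). Its size is a bound rather than a number, and it shows that the chain can matter in this assay. It does not separate isobutyl from butyl, so the data give only weak guidance on direction. A small shift toward a higher number is expected, with little beyond the scatter. The expected change is a 1.7-fold higher number from compound 2 to compound 3 (0.23 log units; within the scatter). For compound 3 the estimated value is 4000 nM, with an expected range of 1200 nM to 15000 nM.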

Compound 3, half-maximal inhibitory concentration: 3680 nM
Beside the measured number, compound 3's estimate is 1.1-fold (0.04 log units) above it, within the range that was stated.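

In this assay, the change from isobutoxycarbonyl to butoxycarbonyl gives a 1.5-fold higher number from compound 2 to compound 3 (0.19 log units; within the scatter), so at this position, on a saturated chain carbon bound to an oxygen next to a carbonyl group, propyl in place of isopropyl leaves the read-out within the usual spread of repeats. The separation from the propoxycarbonyl compound also survives with the unbranched chain, with an at least 5.4-fold lower number from compound 1 to compound 3 (0.73 log units; beyond the scatter), and is therefore not tied to the isobutyl form alone. Compound 1 remains a limit rather than a number, so both steps that start from it give only a bound on their size: the limit of > 20000 nM in this assay, at which 1 of the 3 values shown sits.

The three compounds leave open whether a longer chain such as pentyl moves the number beyond the scatter from compound 2 and compound 3, or whether the response to chain length levels off at butyl and isobutyl. Also open, from the compounds shown here alone, is how this position responds to a group of a different kind, such as benzyl, an amine or a carboxylic acid, in place of these simple saturated chains.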